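The compounds below may be only part of what the source reports. "The series", "measured", "known", "first", "only" and "open" are said of these compounds alone.

Compound 1 `CN(C)CC(=O)OCc1c(F)c(N)c2c(=O)cc(-c3ccc(N)c(F)c3)oc2c1F` gives 9200 nM in a functional assay on HeLa cells (Homo sapiens) for cytotoxicity, read by neutral red uptake, with a stated time of 3 days; on this read-out lower numbers stand for stronger inhibition and higher numbers for weaker inhibition. Compound 2 `COCc1c(F)c(N)c2c(=O)cc(-c3ccc(N)c(F)c3)oc2c1F` reaches only the limit of the assay, > 100000 nM. The step of an at least 10-fold higher number from compound 1 to compound 2 (1.03 log units; beyond the scatter) leaves compound 2 sitting at the limit of > 100000 nM in this assay, at which 1 of the 2 values shown sits. Compound 3 `CCCCCCOCc1c(F)c(N)c2c(=O)cc(-c3ccc(N)c(F)c3)oc2c1F` differs from compound 2 by pentyl in place of hydrogen on a saturated chain carbon bound to an oxygen on a saturated carbon. Among the measured compounds shown here, no measured step covers this change; the single known step concerns the group on the oxygen on a saturated carbon and is large. For compound 3 the expected step of an at least 2.0-fold lower number from compound 2 to compound 3 (0.30 log units; that floor lies within the scatter) is modest, with a fair chance of another limit in this assay. The estimate for compound 3 is therefore 50000 nM, in the range 10000 nM to 200000 nM.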

Compound 3, half-maximal inhibitory concentration: > 100000 nM
Compound 3: no number, only a limit (the forecaster's own chance of this, stated with the estimate: 50%); middle value at least 2.0-fold (0.30 log units) from the limit.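

In this assay compound 3 also gives only a limit, > 100000 nM, so the step from compound 2 cannot be read, and going from methyl to hexyl on this oxygen brings no number into range: the limit of > 100000 nM in this assay, at which 2 of the 3 values shown sit.

With hexyl in place of ((dimethylamino)methyl)carbonyl the record shows an at least 10-fold higher number from compound 1 to compound 3 (1.03 log units; beyond the scatter), so of the three groups on this oxygen only ((dimethylamino)methyl)carbonyl gives a number.

The compounds shown do not separate the contribution of the dimethylamino group from that of the ester carbonyl. An acetyl or a dimethylaminoethyl group on this oxygen would bear on that question.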